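The source may report more compounds than this note shows. Statements on the series, on what has been measured and on what is new or still open speak of the compounds shown alone.

Measured so far in a functional assay on MV4-11 cells (Homo sapiens) for inhibition, read by resazurin assay, with a stated time of 72 h; a lower number here means a stronger inhibitor of growth, a higher number a weaker inhibitor of growth:
compound 1 `COc1ccc(Nc2nccc(-c3cn(C)c4ccccc34)n2)c(OC)c1` gives 3410 nM
compound 2 `COc1ccc(Nc2nccc(-c3sc(SCc4cccnc4)nc3C)n2)c(OC)c1` gives 270 nM
compound 3 `COc1ccc(Nc2nccc(-c3cn(C(C)C)c4ccccc34)n2)c(OC)c1` gives 3250 nM

Compound 2 stands lowest of the three numbers in this assay, beyond the scatter from compound 3 and from compound 1. For the measured compounds named here, compound 1 and compound 3 sit within the scatter of each other; the one step recorded between them, a 1.0-fold lower number from compound 1 to compound 3 (0.02 log units; within the scatter), swaps a group on an aromatic nitrogen of their shared core and moves nothing.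

Compound 4 `CCCSc1nc(C)c(-c2ccnc(Nc3ccc(OC)cc3OC)n2)s1` is compound 2 altered in one place: ethyl in place of pyridin-3-yl on a saturated chain carbon bound to a sulfur. Going by the values given here, no measured step bears on this part of compound 2; the only recorded step, a 1.0-fold lower number from compound 1 to compound 3 (0.02 log units; within the scatter), concerns a different core and a different place and stayed within the scatter, so it serves only as a sign that a small group swap elsewhere cost nothing. Without a direct precedent, the expectation is cautious: the loss of the ring is estimated to give a modest step toward a higher number, a 1.9-fold higher number from compound 2 to compound 4 (0.27 log units; within the scatter), with the chance that it stays within the scatter kept open by a wide range. Compound 4 is therefore expected to give about 500 nM in this assay, between 150 nM and 1800 nM.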

Compound 4, concentration for 50% growth inhibition: 2240 nM
Compound 4: middle estimate off by 4.5-fold (0.65 log units), on the low side, outside the stated range (above it).
By their numbers in this assay, from the lowest: compound 2; then compounds 4, 3 and 1 (each within the scatter of the next).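

In this assay, for the compounds shown here, the group on a saturated chain carbon bound to a sulfur proves to be a place where a single change counts: ethyl in place of pyridin-3-yl gives the series its first step beyond the scatter (an 8.3-fold higher number from compound 2 to compound 4 (0.92 log units; beyond the scatter)), whereas the only earlier step, on a different core and at a different place, stayed within it (a 1.0-fold lower number from compound 1 to compound 3 (0.02 log units; within the scatter)). The change removes a six-membered aromatic ring with 1 hetero atom and 1 hydrogen-bond acceptor, and puts a ringless group of 2 heavy atoms in its place, so the lower number of compound 2 is tied to the pyridin-3-yl-bearing side chain and not to the rest of its structure. No measurement at hand explains this step, so its origin remains unassigned.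

The compounds shown cannot separate the contribution of the aromatic ring from that of its nitrogen, and phenyl at this place would make that distinction. They also leave open whether pyridin-4-yl, an amine or a longer chain would hold the number of compound 2 or follow compound 4.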